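Benzyloxy benzamides: fluoro on the benzyl ring

The compounds below may be only part of what the source reports. "The series", "measured", "known", "first", "only" and "open" are said of these compounds alone.

Measured compounds in an assay on lysate for inhibition of phosphatidylcholine:ceramide cholinephosphotransferase 2 (Homo sapiens), read by HPLC, with stated times of 30 min and 2 h; on this read-out higher numbers stand for weaker inhibition and lower numbers for stronger inhibition:
compound 1, `O=C(NCc1ccco1)c1ccccc1OCc1ccccc1`, 49000 nM
compound 2, `O=C(NC1CCCCC1)c1ccccc1OCc1ccccc1`, 43400 nM
compound 3, `O=C(Nc1cccnc1)c1ccccc1OCc1ccccc1`, 3200 nM

Compound 3 gives the lowest number of the three. The steps leading to it are large: a 15-fold lower number from compound 1 to compound 3 (1.19 log units; beyond the scatter) and a 14-fold lower number from compound 2 to compound 3 (1.13 log units; beyond the scatter), both beyond the scatter, whereas a 1.1-fold lower number from compound 1 to compound 2 (0.05 log units; within the scatter) stays within it. Every measured step alters only the group on the amide-type nitrogen.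

Compound 4, `O=C(Nc1cccnc1)c1ccccc1OCc1cccc(F)c1`, keeps the pyridin-3-yl amide of compound 3 and differs only in the benzyl part: fluoro in place of hydrogen on an aromatic carbon, meta to a large group. Among the measured compounds shown here, no measured step touches the benzyloxy ring, so nothing in the present numbers bears directly on this change. A single fluoro entering at an aromatic carbon is, in the absence of any comparable step here, expected to give a shift no larger than the scatter in this assay, in either direction; the expected step is a 1.1-fold lower number from compound 3 to compound 4 (0.06 log units; within the scatter). Compound 4 is therefore estimated at 2800 nM, with a range from 1000 nM to 9000 nM.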

Compound 4, half-maximal inhibitory concentration: 1600 nM
For compound 4 the middle estimate is 1.8-fold (0.24 log units) above the measured one; low and high end bracket the measured number.
By their numbers in this assay, from the lowest: compounds 4 and 3 (each within the scatter of the next); then compounds 2 and 1 (each within the scatter of the next).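

In this assay, the benzyl ring now has its first measured change, after earlier steps that altered only the group on the amide-type nitrogen: benzyl to 3-fluorobenzyl gives a 2.0-fold lower number from compound 3 to compound 4 (0.30 log units; within the scatter). This aromatic carbon, meta to a large group, therefore takes a fluoro with the pyridin-3-yl amide in place without a step beyond the scatter, and compounds 3 and 4 stand at one level in this series. No measured information accounts for the size of this step.

Still open, from the compounds shown here alone, is how larger groups at this carbon, such as chloro, methoxy or trifluoromethyl, would read. Also open, going by these compounds, is whether fluoro on other carbons of the benzyl ring, or 3-fluorobenzyl with cyclohexyl or (furan-2-yl)methyl on the amide-type nitrogen, would give a similar step.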